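This account rests on a few compounds, and the source may have more. Where it says the series, first, only, none or still open, it means among the compounds named here.

Measured so far in a functional assay on A549 cells (Homo sapiens) for inhibition, read by sulforhodamine B assay, tested at 100 uM; on this read-out higher numbers stand for more inhibition of growth at the one concentration tested and lower numbers for less inhibition of growth:
- compound 2 `COc1cc(C2CC(c3cc(OC)c(OC)c(OC)c3)=NN2C(C)=O)ccc1OCc1cn(Cc2ccc([N+](=O)[O-])cc2)nn1`: 85%
- compound 1 `COc1cc(C2CC(c3ccc([N+](=O)[O-])cc3)=NN2C(C)=O)ccc1OCc1cn(Cc2ccc([N+](=O)[O-])cc2)nn1`: 72%

Compound 2 stands highest of the two numbers, with compound 1 nearest. Among the measured compounds shown here, the single step measured so far, a number 13 percentage points higher from compound 1 to compound 2 (beyond the scatter), was modest yet beyond the scatter.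

Compound 3 `COc1cc(C2CC(c3ccc(Cl)cc3)=NN2C(C)=O)ccc1OCc1cn(Cc2ccc([N+](=O)[O-])cc2)nn1` is the next analogue. Its change: 4-chlorophenyl in place of 3,4,5-trimethoxyphenyl on a carbon with a double bond to nitrogen. For the measured compounds named here, no measured step involves 4-chlorophenyl, so the only bearing is indirect. Going by the values given here, the one step known shows that the 3,4,5-trimethoxyphenyl of compound 2 sits above the 4-nitrophenyl of compound 1 by a number 13 percentage points higher from compound 1 to compound 2 (beyond the scatter). Removing the 3,4,5-trimethoxyphenyl again, for a different small aryl group, is therefore expected to cost part of that gain, with a fall of roughly the same modest size rather than a large one.

The estimate for compound 3 is 70%, with a range of 52% to 86%. The step this implies, a number 15 percentage points lower from compound 2 to compound 3 (beyond the scatter), is expected to lie at the edge of the scatter.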

Compound 3, percent growth inhibition at one concentration: 0%
Beside the measured number, compound 3's estimate is 70 percentage points above it; measured number outside the range, below it.
By their numbers in this assay, from the lowest: compound 3; then compound 1; then compound 2.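

In this assay, the aryl group on the carbon with a double bond to nitrogen turns out to matter far more than the first pair suggested: 4-chlorophenyl in place of 3,4,5-trimethoxyphenyl gives a number 85 percentage points lower from compound 2 to compound 3 (beyond the scatter) and chloro in place of nitro on an aromatic carbon gives a number 72 percentage points lower from compound 1 to compound 3 (beyond the scatter) on the same core. Growth inhibition at this position therefore does not survive every small aryl group, since 4-nitrophenyl and 3,4,5-trimethoxyphenyl keep it while 4-chlorophenyl abolishes it at the concentration tested. No measurement at hand accounts for this loss.

On these data alone, whether a plain phenyl, or a phenyl bearing an amine or a carboxylic acid, would follow compound 3 or compound 2 remains open. Also open, as far as these compounds go, is whether the loss belongs to chloro alone or extends to other halogens such as fluoro or bromo.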